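Adding one methoxy group to compound 2: working notes

The source may hold more compounds than are shown below. What is called first, only, known or untested is meant among the compounds shown, and "the series" means these compounds.

Values in a functional assay on COLO 205 cells (Homo sapiens) for inhibition, read by sulforhodamine B assay; a lower number here means a stronger inhibitor of growth, a higher number a weaker inhibitor of growth:
- compound 1 `COc1cc(-c2ccc(-c3ccc(-c4nc5cc(C)ccc5[nH]4)cc3)cc2)cc(OC)c1OC`: 190 nM
- compound 2 `COc1ccc(-c2ccc(-c3ccc(-c4nc5ccccc5[nH]4)cc3)cc2)cc1OC`: 41200 nM

Compound 2, at 41200 nM, holds the higher of the two numbers and is thus the weaker inhibitor of growth of the pair. Compound 1 lies at 190 nM, and that gap is well beyond the scatter. Going by the values given here, with only two measured compounds, no pattern can be claimed.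

Compound 3 `COc1cc(-c2ccc(-c3ccc(-c4nc5ccccc5[nH]4)cc3)cc2)cc(OC)c1OC` differs from compound 2 through methoxy in place of hydrogen on an aromatic carbon, ortho to a methoxy group. Among the compounds with values here, no measured step isolates this change. The expectation therefore leans on compound 1 at 190 nM, whose methoxy groups compound 3 would share after the change.

The expected size in this assay is a 69-fold lower number from compound 2 to compound 3 (1.84 log units; beyond the scatter), a fall toward lower numbers and beyond the scatter. For compound 3 the estimated value is 600 nM, with an expected range from 130 nM to 6000 nM.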

Compound 3, concentration for 50% growth inhibition: 8320 nM
The estimate for compound 3 lay 14-fold (1.14 log units) below the measured number; the measured number lies above the stated range.
By their numbers in this assay, from the lowest: compound 1; then compound 3; then compound 2.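

In this assay, methoxy in place of hydrogen on an aromatic carbon, ortho to a methoxy group, gives a 5.0-fold lower number from compound 2 to compound 3 (0.69 log units; beyond the scatter), so the step isolated here is beyond the scatter but modest in size. The step back from the other side shows what the earlier pair could not separate: hydrogen in place of methyl on an aromatic carbon gives a 44-fold higher number from compound 1 to compound 3 (1.64 log units; beyond the scatter), a large step and clearly the bigger of the two, so in this small set the methyl group counts for more than the added methoxy. No measurement bearing on either step accompanies these compounds, and the numbers offer no explanation for their sizes.

Open, going by these compounds, is whether methoxy is special at this place or whether a hydroxyl, a fluorine, an ethoxy or an amine on the same aromatic carbon would give a similar step. On these data alone, each step also stands on a single pair, so whether the methyl step holds on the core of compound 2, or whether an ethyl or a chlorine on that carbon would do the same, remains unknown.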